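Cyclic phosphite nucleosides: trifluoromethyl in place of chloro

The source may hold more compounds than are shown below. What is called first, only, known or untested is meant among the compounds shown, and "the series" means these compounds.

Compound 2 `O=c1[nH]c(=O)n([C@H]2C[C@@H]3O[PH](O)(O)OC[C@H]3O2)cc1Cl` is the chloro member of the series. In a functional assay on L1210 cells (Mus musculus) for antiproliferative activity (a higher number here means a weaker inhibitor, a lower number a stronger inhibitor), compound 2 reaches only the assay limit of > 1000 ug/mL, so no number is known for it (the limit of > 1000 ug/mL in this assay, at which 1 of the 3 values shown sits). Its fluoro counterpart, compound 1 `O=c1[nH]c(=O)n([C@H]2C[C@@H]3O[PH](O)(O)OC[C@H]3O2)cc1F`, gives 7.4 ug/mL in this assay. Going by the values given here, the one single-point step measured, an at least 130-fold higher number from compound 1 to compound 2 (2.13 log units; beyond the scatter), therefore marks a large loss on going from fluoro to chloro. Compound 3 `O=c1[nH]c(=O)n([C@H]2C[C@H](O)[C@@H](CO)O2)cc1Cl`, the chloro compound on the open sugar, gives 339 ug/mL in this assay; it is not a single-point neighbour of compound 2 and only the two values themselves can be compared.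

Compound 4 `O=c1[nH]c(=O)n([C@H]2C[C@@H]3O[PH](O)(O)OC[C@H]3O2)cc1C(F)(F)F` is not yet measured. It differs from compound 2 by trifluoromethyl in place of chloro on an aromatic carbon. Among the compounds with values here, no measured step involves a trifluoromethyl group, so the step from compound 2 to compound 4 rests on no direct precedent. Within the data shown here, the only measured step at this position shows that changing the single-atom substituent from fluoro to chloro removed all measurable activity, and compound 2 itself stands at the limit.

On that basis compound 4 is expected to stay weak, near the limit, with an at least 2.0-fold lower number from compound 2 to compound 4 (0.30 log units; that floor lies within the scatter) as the most plausible outcome. The estimate for compound 4 in this assay is 500 ug/mL, within a range of 20 ug/mL to 1000 ug/mL, and a reported limit rather than a number remains quite possible.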

Compound 4, concentration for 50% inhibition: 22 ug/mL
Beside the measured number, compound 4's estimate is 23-fold (1.36 log units) above it; the measured number falls inside the stated range.
By their numbers in this assay, from the lowest: compound 1; then compound 4; then compound 3. At a limit, above all of these: compound 2.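

Compound 2 is held at a limit of the assay, not a number, so any step from it is a floor: the limit of > 1000 ug/mL in this assay, at which 1 of the 4 values shown sits. In this assay, trifluoromethyl in place of chloro brings back measurable activity, with an at least 45-fold lower number from compound 2 to compound 4 (1.65 log units; beyond the scatter), so the loss seen with chloro is not shared by every replacement for fluoro at this position, while trifluoromethyl in place of fluoro costs far less, with a 3.0-fold higher number from compound 1 to compound 4 (0.47 log units; beyond the scatter). Fluoro and chloro are both single atoms, yet the trifluoromethyl group with its 4 heavy atoms falls between them, so heavy-atom count does not order these three compounds.

From the compounds shown here alone, whether an amine, a nitrile or a longer alkyl chain on this aromatic carbon would behave like fluoro and trifluoromethyl or like chloro remains open. Going by these compounds alone, also open is how trifluoromethyl behaves on the open sugar of compound 3, which gives 339 ug/mL in this assay, since no single-point step links that compound to the others.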